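A few compounds are considered here, and "the series" means these few. Any claim that something is new, unique, unknown or untested is made for them only; others in the source may bear on it.

Compound 1 `CCCS(=O)(=O)c1cccc(C#Cc2cc(Cl)ccc2OCC(=O)O)c1` gives 9 nM in an assay on CHO cells for displacement of a labelled ligand from prostaglandin D2 receptor 2 (Homo sapiens), read by scintillation counting; a higher number here means a weaker inhibitor, a lower number a stronger inhibitor.
Compound 2 `Cc1ccc(S(=O)(=O)Cc2ccccc2)cc1C#Cc1cc(Cl)ccc1OCC(=O)O` gives 5 nM in this assay.
Compound 3 `C[S+]([O-])c1cccc(C#Cc2cc(Cl)ccc2OCC(=O)O)c1` gives 3.2 nM in this assay.

For the measured compounds named here, of these three, compound 3 shows the lowest number, but its gap to compound 2 lies within the usual scatter, so the two cannot be ranked; only the step of a 2.8-fold lower number from compound 1 to compound 3 (0.45 log units; beyond the scatter) is beyond the scatter. Compound 4 `CS(=O)(=O)c1cccc(C#Cc2cc(Cl)ccc2OCC(=O)O)c1` differs from compound 3 in one place: a group of 4 heavy atoms (1 carbon, 2 oxygen, 1 sulfur; no ring) in place of a group of 3 heavy atoms (1 carbon, 1 oxygen, 1 sulfur; no ring), on an aromatic carbon. Going by the values given here, no measured pair isolates this exact exchange. The nearest guide is a 2.8-fold lower number from compound 1 to compound 3 (0.45 log units; beyond the scatter), which replaced the group of compound 1 with the group of compound 3 on the same aromatic carbon and lowered the number modestly. Among the compounds with values here, compound 4 carries a methylsulfonyl group, which combines the single carbon of compound 3 with the sulfonyl of compound 1, so a number between those two compounds is expected, most likely staying within the scatter of compound 3. For compound 4 the expected step is a 1.6-fold higher number from compound 3 to compound 4 (0.19 log units; within the scatter), giving an estimate of 5 nM with a range from 2 nM to 13 nM.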

Compound 4, inhibition constant: 15 nM
Estimate against measurement, compound 4: 3.0-fold (0.48 log units) below, and the stated range ends below it.
By their numbers in this assay, from the lowest: compounds 3, 2, 1 and 4 (each within the scatter of the next, the first and the last beyond it).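

Methylsulfonyl in place of the group of compound 3, on the same aromatic carbon, gives a 4.7-fold higher number from compound 3 to compound 4 (0.67 log units; beyond the scatter), so one more oxygen on the sulfur is enough to shift the number here. Hydrogen in place of ethyl on the saturated chain carbon bound to the sulfonyl sulfur gives a 1.7-fold higher number from compound 1 to compound 4 (0.22 log units; within the scatter), so these two sulfonyl compounds cannot be ranked. Among compounds 1, 3 and 4, the lowest number therefore goes with the sulfur group that carries one oxygen, not with the short chain alone.

Nothing at hand gives a reason for this difference. Still open, as far as these compounds go, is how a sulfonamide or a nitrile on this carbon would compare, and whether a longer chain on the one-oxygen sulfur group would leave the number unchanged.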